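Trimming a Fused Ring on a Shared Nucleoside Core

This account rests on a few compounds, and the source may have more. Where it says the series, first, only, none or still open, it means among the compounds named here.

The compounds here share a sugar-bearing core and differ in the groups attached to it. Compound 1 `Nc1nc(N)c2c(-c3cc4ccccc4o3)cn([C@@H]3O[C@H](CO)[C@@H](O)[C@H]3O)c2n1` carries an amino group at one position and, in a functional assay on HCT-116 cells (Homo sapiens), read by MTT assay, with a stated time of 72 h (a higher number here means a weaker inhibitor, a lower number a stronger inhibitor), compound 1 gives 14000 nM. Compound 2 `Cc1nc(N)c2c(-c3cc4ccccc4o3)cn([C@@H]3O[C@H](CO)[C@@H](O)[C@H]3O)c2n1` has a methyl in its place, and in this assay compound 2 gives 13100 nM. The step of a 1.1-fold lower number from compound 1 to compound 2 (0.03 log units; within the scatter) is small. Compound 3 `CSc1ncnc2c1c(-c1ccccc1)cn2[C@@H]1O[C@H](CO)[C@@H](O)[C@H]1O` carries a plain phenyl on the core; in this assay compound 3 reaches only a limit of the assay, > 20000 nM, with no exact number (the limit of > 20000 nM in this assay, at which 1 of the 3 values shown sits).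

On the numbers shown, compound 2 stands lowest of the two exact values, with compound 1 within the scatter of it. Compound 4 `Cc1nc(N)c2c(-c3ccco3)cn([C@@H]3O[C@H](CO)[C@@H](O)[C@H]3O)c2n1` is not yet measured. It differs from compound 2 in one place: furan-2-yl in place of 1-benzofuran-2-yl on an aromatic carbon.

Going by the values given here, none of the measured steps touches this change; the only measured step, a 1.1-fold lower number from compound 1 to compound 2 (0.03 log units; within the scatter), concerns a different group. The step to compound 4 is therefore uncertain, and a value at or beyond the limit of the assay is possible. Compound 4 is expected to give 22000 nM, between 8000 nM and 60000 nM, meaning an expected step of a 1.7-fold higher number from compound 2 to compound 4 (0.23 log units; within the scatter).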

Compound 4, half-maximal inhibitory concentration: > 20000 nM
Compound 4 was reported as a limit (the forecaster's own chance of this, stated with the estimate: 45%); the middle value is on the limit's open side.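

Going by these compounds alone, the only earlier step changed a different group, so this is the first look at the aromatic carbon of the five-membered ring, where 1-benzofuran-2-yl is trimmed to furan-2-yl and the six-membered aromatic ring of carbon only is lost. In this assay compound 4 gives > 20000 nM, which is a limit of the assay and not an exact number. The step reads an at least 1.5-fold higher number from compound 2 to compound 4 (0.18 log units; that floor lies within the scatter), so trimming the fused ring brings no measurable gain in strength, but this floor cannot establish a real loss, and one more compound now rests at the limit: the limit of > 20000 nM in this assay, at which 2 of the 4 values shown sit.

From the compounds shown here alone, how much strength, if any, depends on the fused ring stays open, since a limit gives no true size for this step. Also unknown is how this position would respond to a thiophene ring, a naphthalene ring, or a furan ring carrying an amine or a carboxylic acid, any of which could show whether the position tolerates other groups.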